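Thiophene to dimethylthiazole on the cyclopropane of compound 3

A few compounds are considered here, and "the series" means these few. Any claim that something is new, unique, unknown or untested is made for them only; others in the source may bear on it.

Compound 1, `CC[C@H](C)[C@H](N)CN(C(=O)[C@@H]1C[C@H]1c1ccc(F)cc1F)c1ccc(-c2ccccc2)cc1`, gives 1300 nM in a functional assay for agonist activity at G protein-coupled receptor 88 (Homo sapiens), read by HTRF and cAMP accumulation; on this read-out higher numbers stand for an effect only at larger amounts of compound and lower numbers for an effect already at smaller amounts.
Compound 2, `CC[C@H](C)[C@H](N)CN(C(=O)[C@@H]1C[C@H]1c1cncnc1)c1ccc(-c2ccccc2)cc1`, gives 19000 nM in this assay.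
Compound 3, `CC[C@H](C)[C@H](N)CN(C(=O)[C@@H]1C[C@H]1c1cccs1)c1ccc(-c2ccccc2)cc1`, gives 360 nM in this assay.

Of these three, compound 3 has the lowest number in this assay, so it acts at the smallest amounts. Its nearest neighbour is compound 1, and the step of a 3.6-fold lower number from compound 1 to compound 3 (0.56 log units; beyond the scatter) lies beyond the scatter; compound 2 is furthest off, with a 53-fold lower number from compound 2 to compound 3 (1.72 log units; beyond the scatter). Compound 4, `CC[C@H](C)[C@H](N)CN(C(=O)[C@@H]1C[C@H]1c1nc(C)c(C)s1)c1ccc(-c2ccccc2)cc1`, has not yet been measured. It differs from compound 3 only in one place: 4,5-dimethyl-1,3-thiazol-2-yl in place of thiophen-2-yl on a saturated ring carbon. For the measured compounds named here, two measured steps touch the same position. Replacing the 2,4-difluorophenyl ring by a five-membered thiophene helped, seen in a 3.6-fold lower number from compound 1 to compound 3 (0.56 log units; beyond the scatter), whereas replacing it by a six-membered ring with two nitrogens hurt sharply, seen in a 15-fold higher number from compound 1 to compound 2 (1.16 log units; beyond the scatter). The new group keeps the five-membered sulfur ring of compound 3 but adds a nitrogen and two methyl groups, so a moderate rise in the number is expected rather than a collapse. The expected step for compound 4 is a 3.3-fold higher number from compound 3 to compound 4 (0.52 log units; beyond the scatter). In this assay compound 4 is estimated at 1200 nM, between 300 nM and 5000 nM.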

Compound 4, half-maximal effective concentration: 3600 nM
Beside the measured number, compound 4's estimate is 3.0-fold (0.48 log units) below it; measured number inside the range.
By their numbers in this assay, from the lowest: compound 3; then compound 1; then compound 4; then compound 2.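

The low number of compound 3 does not come from a five-membered aromatic ring with sulfur alone: in this assay, 4,5-dimethyl-1,3-thiazol-2-yl in place of thiophen-2-yl gives a 10-fold higher number from compound 3 to compound 4 (1.00 log units; beyond the scatter) and so loses much of the gain. The new group also falls behind 2,4-difluorophenyl, with a 2.8-fold higher number from compound 1 to compound 4 (0.44 log units; beyond the scatter), yet it still improves on pyrimidin-5-yl, with a 5.3-fold lower number from compound 2 to compound 4 (0.72 log units; beyond the scatter), so ring size alone does not set the order at this position. Nothing measured here explains these differences.

The compounds shown cannot separate the effect of the ring nitrogen from that of the two methyl groups; a plain 1,3-thiazol-2-yl ring, or a thiophene carrying methyl groups, would pull them apart. They also leave open how this assay would respond to an amine or a carboxylic acid on the thiophene ring.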